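The source may hold more compounds than are shown below. What is called first, only, known or untested is meant among the compounds shown, and "the series" means these compounds.

Measured in a functional assay on the whole organism for inhibition, with Cavia porcellus as the target, with a stated time of 2 h; on this read-out higher numbers stand for an effect only at larger amounts of compound and lower numbers for an effect already at smaller amounts:
- Compound 1 `CCCC/C(=C\C=C\C(=O)N[C@H](C)CCCc1cccnc1)c1ccc(OC)cc1`: 12 mg/kg
- Compound 2 `COc1ccc(C(=C/C=C/C(=O)NCCCCc2cccnc2)c2ccc(OC)c(OC)c2)cc1OC`: 27 mg/kg
- Compound 3 `COc1ccc(C(=C/C=C/C(=O)NC(C)(C)CCCc2cccnc2)c2ccc(OC)cc2)cc1`: 55 mg/kg

Among these three, compound 1 has the lowest number and therefore shows its effect at the smallest dose. Both of the others lie beyond the usual scatter from it, with compound 2 at 27 mg/kg and compound 3 at 55 mg/kg.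

The next compound to be tested is compound 4 `COc1ccc(/C(=C/C=C/C(=O)N[C@H](C)CCCc2cccnc2)C(C)C)cc1`, which keeps the core of compound 1 but carries isopropyl in place of butyl on a double-bonded chain carbon bound to an aromatic carbon and a double-bonded chain carbon.

Among the measured compounds shown here, no two measured compounds differ in one place only, so the data offer no direct precedent for this exchange. The expectation in this assay is therefore cautious. Since compound 1, at 12 mg/kg, sits at the low end of the numbers seen so far, a modest move towards a higher number seems more likely than a move lower, and it may stay within the scatter. The expected step is a 1.7-fold higher number from compound 1 to compound 4 (0.22 log units; within the scatter). For compound 4 the estimated value is 20 mg/kg, with an expected range of 7 mg/kg to 60 mg/kg.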

Compound 4, dose for 50% inhibition: 30 mg/kg
Compound 4: the middle estimate sits 1.5-fold (0.18 log units) below what was measured, within the range that was stated.
By their numbers in this assay, from the lowest: compound 1; then compounds 2, 4 and 3 (each within the scatter of the next, the first and the last beyond it).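

In this assay, among the compounds shown here, exchanging butyl for isopropyl gives a 2.5-fold higher number from compound 1 to compound 4 (0.40 log units; beyond the scatter), the first step here that changes one place only, and it shows that the group at this position affects the dose needed. The exchange involves only carbon groups, butyl with 4 heavy atoms and isopropyl with 3, neither bringing a ring, a hydrogen-bond donor or acceptor, or a net charge, yet the step still lies beyond the usual scatter, although it is modest. No measurement shown here explains why the number moves in this direction.

For the compounds shown here, the single step cannot separate the loss of one carbon from the change in chain shape, and it remains open whether propyl, a longer chain such as hexyl, or a cyclopropyl group at this carbon would match compound 1 or move further from it. Going by these compounds, it is also open whether the same exchange would give a similar step on a different amide side chain, such as one carrying a primary amine.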